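The compounds below may be only part of what the source reports. "The series", "measured", "known", "first", "only" and "open" are said of these compounds alone.

Of the compounds shown here, three sharing one core have been tested in a functional assay on DU-145 cells (Homo sapiens) for cytotoxicity; a lower number here means a stronger inhibitor of growth, a higher number a weaker inhibitor of growth. Compound 1 `COc1ccc(C2=C(c3ccc(SC)cc3)CC3CCCN3C2=O)cc1O`, which carries a hydroxy group, gives 6000 nM. Compound 2 `COc1ccc(C2=C(c3ccc(SC)cc3)CC3CCCN3C2=O)cc1OC(=O)CNC(=O)OC(C)(C)C`, its ester on that oxygen, gives 10000 nM, and the step between them is a 1.7-fold higher number from compound 1 to compound 2 (0.22 log units; within the scatter). Compound 3 `COc1ccc(C2=C(c3ccc(SC)cc3)CC3CCCN3C2=O)cc1C` gives 900 nM, the lowest number of the three, which makes it the strongest inhibitor of growth in this small set.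

Compound 4 `COc1ccc(C2=C(c3ccc(SC)cc3)CC3CCCN3C2=O)cc1OC` differs from compound 3 in one place, with methoxy in place of methyl on an aromatic carbon, ortho to a methoxy group: methoxy in place of methyl on an aromatic carbon. Among the compounds with values here, no measured step makes this exact change. The nearest are a 6.7-fold lower number from compound 1 to compound 3 (0.82 log units; beyond the scatter) and an 11-fold lower number from compound 2 to compound 3 (1.05 log units; beyond the scatter), and each puts methyl where an oxygen-linked group stood. Read in reverse, they suggest that an oxygen at that carbon should raise the number, though no tested compound has methoxy there, so the size remains uncertain. The expected step is modest, a 2.2-fold higher number from compound 3 to compound 4 (0.35 log units; beyond the scatter). Compound 4 is estimated at 2000 nM, with an expected range of 600 nM to 6000 nM.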

Compound 4, concentration for 50% growth inhibition: 1500 nM
For compound 4 the middle estimate is 1.3-fold (0.12 log units) above the measured one, and the stated range covers the measured number.
By their numbers in this assay, from the lowest: compounds 3 and 4 (each within the scatter of the next); then compounds 1 and 2 (each within the scatter of the next).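

At this aromatic carbon, ortho to a methoxy group, methoxy and methyl could not be told apart in this assay (a 1.7-fold higher number from compound 3 to compound 4 (0.22 log units; within the scatter)), so an oxygen there did not by itself carry the weaker growth inhibition of compound 1 and compound 2. What mattered among these compounds was the group on that oxygen: methyl in place of hydrogen gave (a 4.0-fold lower number from compound 1 to compound 4 (0.60 log units; beyond the scatter)), and methyl in place of the (((tert-butoxycarbonyl)amino)methyl)carbonyl group gave (a 6.7-fold lower number from compound 2 to compound 4 (0.82 log units; beyond the scatter)). Nothing available explains why these steps fall as they do.

Going by these compounds, it remains open whether a longer chain on that oxygen, such as ethoxy, would keep the number near those of compound 3 and compound 4. Also open, on these data alone, is how an amine or a fluorine at that carbon would read.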